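Trading an Acetamido Group for a Hydroxy Group

The compounds below may be only part of what the source reports. "The series", "measured", "known", "first", "only" and "open" are said of these compounds alone.

Of the compounds shown here, three built on the same core have been measured so far, each carrying a different amine on one aromatic carbon. Compound 1 `OCCCNc1ncnc2[nH]cc(-c3cccc(Cl)c3)c12` gives 173 nM in an assay for inhibition of serine/threonine-protein kinase 3 (Homo sapiens), read by luminescence and ADP-Glo, in the presence of a further agent that is not named here; on this read-out higher numbers stand for weaker inhibition and lower numbers for stronger inhibition. Compound 2 `CCCN(C)c1ncnc2[nH]cc(-c3cccc(Cl)c3)c12` gives 218 nM in this assay, and the step of a 1.3-fold higher number from compound 1 to compound 2 (0.10 log units; within the scatter) shows that this swap hardly matters. Compound 3 `CC(=O)NC1CCN(c2ncnc3[nH]cc(-c4cccc(Cl)c4)c23)CC1` gives 36 nM in this assay, the lowest of the three numbers, so compound 3 is the strongest inhibitor of the set.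

Compound 4 `OC1CCN(c2ncnc3[nH]cc(-c4cccc(Cl)c4)c23)CC1` is derived from compound 3 by the change (hydroxy in place of acetamido on a saturated ring carbon). Within the data shown here, no measured step touches this saturated ring carbon; the only step in hand, a 1.3-fold higher number from compound 1 to compound 2 (0.10 log units; within the scatter), concerns a different position and lay within the scatter, so it offers no direct guide. The larger acetamido group in compound 3 goes with the best number seen, and its loss is expected to cost some potency. Compound 4 is therefore expected to show a step of a 2.1-fold higher number from compound 3 to compound 4 (0.32 log units; beyond the scatter), with an estimate of 75 nM and a range from 25 nM to 220 nM.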

Compound 4, half-maximal inhibitory concentration: 127 nM
Beside the measured number, compound 4's estimate is 1.7-fold (0.23 log units) below it; low and high end bracket the measured number.
By their numbers in this assay, from the lowest: compound 3; then compounds 4, 1 and 2 (each within the scatter of the next).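

Among these compounds, this is the first step at this saturated ring carbon: hydroxy in place of acetamido gives (a 3.5-fold higher number from compound 3 to compound 4 (0.55 log units; beyond the scatter)), so with the rest of compound 3 kept, the group on this carbon alone moves the number beyond the scatter. With hydroxy there, the 4-hydroxypiperidin-1-yl group cannot be told apart from either chain-bearing amine (a 1.4-fold lower number from compound 1 to compound 4 (0.13 log units; within the scatter); a 1.7-fold lower number from compound 2 to compound 4 (0.23 log units; within the scatter)), as both steps lie within the scatter. Nothing available here explains the difference between acetamido and hydroxy.

The compounds shown leave open whether the whole acetamido group is needed or only part of it. A plain amine on this ring carbon, or a longer amide such as propanamido, would help to separate the contribution of the carbonyl from that of the chain length.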